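This account rests on a few compounds, and the source may have more. Where it says the series, first, only, none or still open, it means among the compounds named here.

Of the compounds shown here, two sharing one core have so far been measured. Compound 1 `CCCCO[C@H](c1ccc(O)c(O)c1)[C@H](CC#Cc1ccc(O)c(O)c1)O[C@@H]1O[C@H](CO)[C@@H](O)[C@H](O)[C@H]1O` carries a butyl on an oxygen on a saturated carbon, and in a functional assay on heart right ventricle (Rattus norvegicus, strain WKY), tested at 3 uM (on this read-out higher numbers stand for a weaker effect at the one concentration tested and lower numbers for a stronger effect), compound 1 gives 96.8%. Compound 2 `OC[C@H]1O[C@@H](O[C@@H](CC#Cc2ccc(O)c(O)c2)[C@H](O)c2ccc(O)c(O)c2)[C@H](O)[C@@H](O)[C@@H]1O` differs from it by hydrogen in place of that butyl, and in this assay compound 2 gives 83.6%. Going by the values given here, the single step known, a number 13.2 percentage points lower from compound 1 to compound 2 (beyond the scatter), is the only guide available. Compound 2 thus stands lowest of the two numbers, its nearest neighbour being compound 1, and the gap between them lies beyond the scatter.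

Compound 3 `CO[C@H](c1ccc(O)c(O)c1)[C@H](CC#Cc1ccc(O)c(O)c1)O[C@@H]1O[C@H](CO)[C@@H](O)[C@H](O)[C@H]1O` is the next member. Its change from compound 2 is methyl in place of hydrogen on an oxygen on a saturated carbon. Among the compounds with values here, only the step from compound 1 to compound 2 bears on this move, and it ran downward by a number 13.2 percentage points lower from compound 1 to compound 2 (beyond the scatter) when butyl was removed. Putting a methyl back on the same oxygen reverses part of that removal, so in this assay a rise is expected for compound 3, smaller than the earlier step and possibly inside the scatter, amounting to a number 6.4 percentage points higher from compound 2 to compound 3 (within the scatter). Compound 3 is therefore estimated to give 90%, in the range 79% to 100%.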

Compound 3, a percentage reported as activity, at one concentration (the size of the read-out at that concentration, not a potency): 106%
For compound 3 the middle estimate is 16 percentage points below the measured one, and the stated range ends below it.
By their numbers in this assay, from the lowest: compound 2; then compounds 1 and 3 (each within the scatter of the next).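

In this assay, the methyl on this oxygen does not stop part-way back towards compound 1: hydroxy to methoxy reads as a number 22.4 percentage points higher from compound 2 to compound 3 (beyond the scatter), so even the smallest group shown on this oxygen removes the whole of the drop seen on losing butyl. Butyl and methyl cannot be told apart here, with a number 9.2 percentage points higher from compound 1 to compound 3 (within the scatter), which leaves compound 2, the only one of the three with a free hydroxy at this position, as the only compound that stands apart from the others, while the length of the chain on the oxygen makes no difference that can be read between these two ethers. No measurement is available that explains why capping this oxygen separates compound 2 from the other two.

The compounds shown leave open whether an ethyl or propyl chain, an acetyl ester or an amine-bearing chain on this oxygen would fall with the two ethers or with compound 2. They also leave open how these compounds compare at other concentrations, as the read-out comes from a single concentration and gives no potency.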